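Fluorine count on the phenoxy tail of carbamate inhibitors

The source may report more compounds than this note shows. Statements on the series, on what has been measured and on what is new or still open speak of the compounds shown alone.

Compound 1, `CCCCNC(=O)Oc1cccc(-n2ccc(C(N)=O)c2)c1`: 60 nM
Compound 2, `CCCCNC(=O)Oc1cccc(-c2oc(C)cc2C(N)=O)c1`: 140 nM
Compound 3, `NC(=O)c1ccn(-c2cccc(OC(=O)NCCOCCOc3ccccc3F)c2)c1`: 18 nM

All three were measured in an assay (brain) for inhibition of Fatty-acid amide hydrolase 1 (Mus musculus), with stated times of 20 min and 15 min; a lower number here means a stronger inhibitor, a higher number a weaker inhibitor. Compound 3 gives the lowest of the three numbers: compound 1 sits higher by a margin beyond the scatter, and compound 2 sits higher still, also beyond the scatter. Compound 4, `NC(=O)c1ccn(-c2cccc(OC(=O)NCCOCCOc3c(F)cc(F)cc3F)c2)c1`, has not yet been measured. Compared with compound 3 it differs in one place: 2,4,6-trifluorophenyl in place of 2-fluorophenyl on an oxygen on a saturated carbon, so the change reads 2-fluorophenoxy to 2,4,6-trifluorophenoxy. Among the measured compounds shown here, no measured pair shows this change, so its size cannot be taken from the data. Since the shared core and the carbamate of compound 3 are kept, and only the phenyl at the end of the chain changes, a step no larger than the scatter, in either direction, is expected. Compound 4 is therefore expected near 20 nM, with a range from 7 nM to 60 nM. This estimate amounts to a step of a 1.1-fold higher number from compound 3 to compound 4 (0.05 log units; within the scatter), which is expected to stay within the scatter.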

Compound 4, inhibition constant: 11 nM
Compound 4: middle estimate off by 1.8-fold (0.26 log units), on the high side; the measured number falls inside the stated range.
By their numbers in this assay, from the lowest: compounds 4 and 3 (each within the scatter of the next); then compound 1; then compound 2.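

In this assay, the exchange of 2-fluorophenyl for 2,4,6-trifluorophenyl on an oxygen on a saturated carbon gives a 1.6-fold lower number from compound 3 to compound 4 (0.21 log units; within the scatter), so the two compounds cannot be told apart in this measurement. Among the compounds shown here, this is the first measured change at the end of the chain, and it shows that the position accepts a 2,4,6-trifluorophenoxy group in place of 2-fluorophenoxy with no step beyond the scatter, at least on the shared core of these two compounds. No measurement of any property bears on this result, so it remains a plain observation on one pair.

The compounds shown leave open how an unsubstituted phenoxy group, or an amine or a carboxylic acid on the phenyl ring, would behave at this position. They also leave open whether the same fluorine change would give a similar step on a longer chain or on the core of compound 2.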